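A few compounds are considered here, and "the series" means these few. Any claim that something is new, unique, unknown or untested is made for them only; others in the source may bear on it.

In an assay for inhibition of Alpha amylase (Homo sapiens), with a stated time of 10 min (on this read-out lower numbers stand for stronger inhibition and higher numbers for weaker inhibition), compound 1 `COc1ccc(Br)c(-c2nc3cc(F)ccc3[nH]2)c1O` gives 2170 nM. Compound 2 `Oc1c(Br)cc(Cl)cc1-c1nc2cc(F)ccc2[nH]1` gives 2860 nM in this assay, and compound 3 `Oc1c(Br)cc(Cl)cc1-c1nc2cc(Cl)ccc2[nH]1` gives 2860 nM in the same assay. The difference between the cores of compound 1 and compound 2 is not broken down here. Compound 2 and compound 3 differ by chloro in place of fluoro on an aromatic carbon, and this change gave no change at the digits printed from compound 2 to compound 3 (within the scatter). Among the measured compounds shown here, compound 4 `COc1ccc(Br)c(-c2nc3cc(Cl)ccc3[nH]2)c1O` has not yet been measured in this assay; it differs from compound 1 by chloro in place of fluoro on an aromatic carbon, which is the same change as the one between compound 2 and compound 3. Because compound 1 gives 2170 nM and the earlier step was no change at the digits printed from compound 2 to compound 3 (within the scatter), the step expected here is a 1.0-fold higher number from compound 1 to compound 4 (0.01 log units; within the scatter). Compound 4 is therefore estimated at 2200 nM, expected to lie between 1100 nM and 4400 nM.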

Compound 4, half-maximal inhibitory concentration: 2210 nM
Compound 4: the middle estimate sits 1.0-fold (0.00 log units) below what was measured; low and high end bracket the measured number.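

In this assay, chloro in place of fluoro on an aromatic carbon gave a 1.0-fold higher number from compound 1 to compound 4 (0.01 log units; within the scatter), and this step matches the earlier one on the other core: the same change on two cores in this assay, no change at the digits printed (within the scatter) from compound 2 to compound 3 and a 1.0-fold higher number (0.01 log units; within the scatter) from compound 1 to compound 4, 1.0-fold (0.01 log units) apart, within the scatter of two such steps

On these two cores, the change therefore carried over, and the step read on one core held on the other. Among the compounds shown here, this does not establish a rule for the whole series, as it rests on only two pairs in one assay and does not show that the step would hold on a further core.

Only fluoro and chloro appear at this place in the compounds shown. From the compounds shown here alone, it remains open whether an amine or a carboxylic acid there would shift the number beyond the scatter.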